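Chain extension on a nucleoside core: cytotoxicity expected unchanged

This account rests on a few compounds, and the source may have more. Where it says the series, first, only, none or still open, it means among the compounds named here.

Compound 2 `CCCCCCc1cc2cn([C@H]3C[C@H](O)[C@@H](CO)O3)c(=O)nc2s1` is the longer-chain member of the measured pair. In a functional assay on HEL cells (Homo sapiens) for cytotoxicity (on this read-out higher numbers stand for lower toxicity in this test and lower numbers for higher toxicity in this test), compound 2 reaches only a limit of the assay, > 200000 nM. Compound 1 `CCCCc1cc2cn([C@H]3C[C@H](O)[C@@H](CO)O3)c(=O)nc2s1` likewise sits at a limit in this assay, > 200000 nM. The step that the two limits leave unreadable from compound 1 to compound 2 cannot be read, since both values sit at the limit of > 200000 nM in this assay, at which 2 of the 2 values shown sit. Compound 3 `CCCCCCCCc1cc2cn([C@H]3C[C@H](O)[C@@H](CO)O3)c(=O)nc2s1` differs from compound 2 by ethyl in place of hydrogen on a saturated chain carbon, six bonds along the chain from an aromatic carbon. Within the data shown here, the only comparable step gives no readable size, so no direction can be drawn from it. Compound 3 is therefore expected to remain at the same limit, with an estimated step of a number no higher from compound 2 to compound 3 (the limit leaves the size open). The estimated value for compound 3 is 200000 nM, with a range from 80000 nM to 500000 nM.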

Compound 3, half-maximal cytotoxic concentration: 53000 nM
Estimate against measurement, compound 3: 3.8-fold (0.58 log units) above; measured number outside the range, below it.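

In this assay this chain position does respond: ethyl in place of hydrogen, six bonds along the chain from an aromatic carbon, gives an at least 3.7-fold lower number from compound 2 to compound 3 (0.57 log units; beyond the scatter). Butyl in place of hydrogen, four bonds along the chain from an aromatic carbon, gives an at least 3.7-fold lower number from compound 1 to compound 3 (0.57 log units; beyond the scatter). Going by these compounds, compound 3 is the only one of the three with a number rather than a limit, so both steps stay open-ended: the limit of > 200000 nM in this assay, at which 2 of the 3 values shown sit. On these data alone, whether a longer chain lowers the number further remains open. So does whether a chain ending in an amine or a carboxylic acid would follow the same course.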